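The source may hold more compounds than are shown below. What is called first, only, known or untested is meant among the compounds shown, and "the series" means these compounds.

Measured so far in a functional assay on HCT-116 cells (Homo sapiens) for inhibition; a lower number here means a stronger inhibitor, a higher number a weaker inhibitor:
- Compound 1 `CC(=O)Oc1ccc(/C=C/c2ccc3ccccc3c2)cc1`: > 5000 nM
- Compound 2 `Cc1ccc(/C=C/c2ccc3ccccc3c2)cc1`: > 5000 nM

Both entries are limits of the assay, not numbers.

Compound 2 gives > 5000 nM as a limit, so its standing in the series is known only as a limit and not as a number. The next compound is compound 3 `CN(C)c1ccc(/C=C/c2ccc3ccccc3c2)cc1`, not yet measured in this assay. The change is dimethylamino in place of methyl on an aromatic carbon, para to a large group.

Among the compounds with values here, only one measured step bears on this change, namely a step that the two limits leave unreadable from compound 1 to compound 2, and it gives no size to carry over. The evidence in hand amounts to the limit of > 5000 nM in this assay, at which 2 of the 2 values shown sit. With no readable step, no shift in a particular direction can be argued, and the working expectation is that compound 3 stays close to the same limit and may well be reported as a limit again. The estimated step is a step that the limit leaves unreadable from compound 2 to compound 3, with wide uncertainty. The expected value for compound 3 is 6000 nM, with an estimated range from 1500 nM to 20000 nM.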

Compound 3, half-maximal inhibitory concentration: 3660 nM
Estimate against measurement, compound 3: 1.6-fold (0.21 log units) above; the measured number falls inside the stated range.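

In this assay, compound 3 is the only compound shown with a number rather than a limit, at 3660 nM, so this aromatic carbon, para to a large group, can carry a group that brings the read-out within the measurable range. Dimethylamino gives an at least 1.3-fold lower number from compound 2 to compound 3 (0.13 log units; that floor lies within the scatter), and in place of acetoxy it gives an at least 1.3-fold lower number from compound 1 to compound 3 (0.13 log units; that floor lies within the scatter). Both steps are floors only, the step between the two limited compounds cannot be read, and the rest of the series remains at the assay limit: the limit of > 5000 nM in this assay, at which 2 of the 3 values shown sit.

The compounds shown leave open how large either step really is, and whether compound 3 differs from the other two by more than the usual scatter. They also leave open whether the nitrogen or the size of dimethylamino matters at this place, a question that an amino, methoxy or diethylamino group on the same carbon of the shared core would address.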